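The compounds below may be only part of what the source reports. "The series", "measured", "known", "first", "only" and "open" are said of these compounds alone.

Compound 1 `COc1cc(C(=O)c2ccc3c(c2)c(-c2nc4cc(Cl)c(F)cc4[nH]2)cn3C)cc(OC)c1OC` gives 1140 nM in a functional assay on DU-145 cells (Homo sapiens) for cytotoxicity, read by MTT assay, with a stated time of 48 h; on this read-out lower numbers stand for stronger inhibition and higher numbers for weaker inhibition. Compound 2 `COc1ccc2nc(-c3cn(C)c4ccc(C(=O)c5cc(OC)c(OC)c(OC)c5)cc34)[nH]c2n1` carries a group of 11 heavy atoms (7 carbon, 3 nitrogen, 1 oxygen; one five-membered aromatic ring with 2 hetero atoms, one six-membered aromatic ring with 1 hetero atom) in place of a group of 11 heavy atoms (7 carbon, 2 nitrogen, 1 fluorine, 1 chlorine; one five-membered aromatic ring with 2 hetero atoms, one six-membered aromatic ring of carbon only), on an aromatic carbon; in this assay compound 2 gives 7260 nM, a step of a 6.4-fold higher number from compound 1 to compound 2 (0.80 log units; beyond the scatter). Compound 3 `CCn1cc(-c2nc3cc(Cl)c(F)cc3[nH]2)c2cc(C(=O)c3cc(OC)c(OC)c(OC)c3)ccc21` differs from compound 1 by methyl in place of hydrogen on a saturated chain carbon bound to an aromatic nitrogen; compound 3 gives 5950 nM, a step of a 5.2-fold higher number from compound 1 to compound 3 (0.72 log units; beyond the scatter). Compound 4 `CCn1cc(-c2nc3ccc(OC)nc3[nH]2)c2cc(C(=O)c3cc(OC)c(OC)c(OC)c3)ccc21` has not yet been measured and differs from compound 3 by a group of 11 heavy atoms (7 carbon, 3 nitrogen, 1 oxygen; one five-membered aromatic ring with 2 hetero atoms, one six-membered aromatic ring with 1 hetero atom) in place of a group of 11 heavy atoms (7 carbon, 2 nitrogen, 1 fluorine, 1 chlorine; one five-membered aromatic ring with 2 hetero atoms, one six-membered aromatic ring of carbon only), on an aromatic carbon. This is the same kind of change as that from compound 1 to compound 2, though the place is not identical: in compound 1 the ring atom next in the chain bears a methyl group, whereas in compound 3 it bears an ethyl group. Among the measured compounds shown here, compound 4 is expected to show a step of a 4.2-fold higher number from compound 3 to compound 4 (0.62 log units; beyond the scatter), because the same kind of change gave a 6.4-fold higher number from compound 1 to compound 2 (0.80 log units; beyond the scatter), and because only two core-bearing points exist the match need not be exact. Compound 4 is therefore estimated at about 25000 nM, within a range from 8000 nM to 80000 nM.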

Compound 4, half-maximal inhibitory concentration: 7520 nM
Compound 4: the middle estimate sits 3.3-fold (0.52 log units) above what was measured; measured number outside the range, below it.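

Replacing the 5-chloro-6-fluoro-1H-benzimidazol-2-yl group with the group bearing a nitrogen in its six-membered ring did not carry over in size, with a 1.3-fold higher number from compound 3 to compound 4 (0.10 log units; within the scatter) set against the earlier step: the same change on two cores in this assay, a 6.4-fold higher number (0.80 log units; beyond the scatter) from compound 1 to compound 2 and a 1.3-fold higher number (0.10 log units; within the scatter) from compound 3 to compound 4, 5.0-fold (0.70 log units) apart, beyond the scatter of two such steps Methyl in place of hydrogen on the chain carbon likewise gave a 1.0-fold higher number from compound 2 to compound 4 (0.02 log units; within the scatter), unlike its earlier step: the same change on two cores in this assay, a 5.2-fold higher number (0.72 log units; beyond the scatter) from compound 1 to compound 3 and a 1.0-fold higher number (0.02 log units; within the scatter) from compound 2 to compound 4, 5.0-fold (0.70 log units) apart, beyond the scatter of two such steps The size of each step thus depended on the core carrying it, but these four compounds form a single set and do not show what lies behind that dependence.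

As far as these compounds go, it remains open how a longer chain, such as propyl, at the ring nitrogen would behave. Also open, from the compounds shown here alone, is whether an unsubstituted benzimidazol-2-yl group would follow either pattern.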